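Removing the trifluoromethyl of compound 1

The compounds below may be only part of what the source reports. "The series", "measured", "known", "first", "only" and "open" are said of these compounds alone.

Going by the values given here, in an ADME assay on HEK293 cells (Homo sapiens) for cytotoxicity, read by resazurin assay, with a stated time of 48 h (a lower number here means that less compound is tolerated, a higher number that more compound is tolerated), compound 1 `O=S(=O)(Nc1ccc(-c2nc3ccccc3o2)cc1)c1ccc(Cl)c(C(F)(F)F)c1` gives 69000 nM, the lowest of the three numbers known, though both other compounds sit within the scatter of it. Compound 2 `O=S(=O)(Nc1ccc(-c2nc3ccccc3o2)cc1)c1ccc(F)c(C(F)(F)F)c1` gives 82000 nM, reached by the step of a 1.2-fold higher number from compound 1 to compound 2 (0.07 log units; within the scatter). Compound 3 `O=[N+]([O-])c1cc(S(=O)(=O)Nc2ccc3oc(-c4ccccc4)nc3c2)ccc1Cl` gives 90000 nM; no single change links it to compound 1, so the two values are only set side by side. The unmeasured compound 4 `O=S(=O)(Nc1ccc(-c2nc3ccccc3o2)cc1)c1ccc(Cl)cc1` differs from compound 1 in one place: hydrogen in place of trifluoromethyl on an aromatic carbon. Among the compounds with values here, no measured step removes a trifluoromethyl. Within the data shown here, the one step measured, a 1.2-fold higher number from compound 1 to compound 2 (0.07 log units; within the scatter), exchanges one halogen for another and stays within the scatter, and all three values fall in a narrow band. Nothing in the set therefore points to a change beyond the scatter. The step expected in this assay is a 1.1-fold higher number from compound 1 to compound 4 (0.04 log units; within the scatter), within the scatter. Compound 4 is estimated at 75000 nM, with a range from 35000 nM to 160000 nM.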

Compound 4, half-maximal cytotoxic concentration: > 100000 nM
Compound 4 ended at the assay's limit (the forecaster's own chance of this, stated with the estimate: 15%); middle value at least 1.3-fold (0.12 log units) from the limit.
By their numbers in this assay, from the lowest: compounds 1, 2 and 3 (each within the scatter of the next). At a limit, above all of these: compound 4.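

In this assay compound 4, with hydrogen in place of trifluoromethyl, gives > 100000 nM, which is a limit of the assay and not a number. The earlier compounds shown here held no step at this carbon, ortho to a chloro group, and the change now reads as an at least 1.4-fold higher number from compound 1 to compound 4 (0.16 log units; that floor lies within the scatter), so it has a floor but no measured size, and that floor alone does not separate the pair. Compound 4 is the only one of the set at the limit: the limit of > 100000 nM in this assay, at which 1 of the 4 values shown sits.

As far as these compounds go, how far the true value of compound 4 lies from that of compound 1, and whether the gap passes the scatter, stays open. Also open, from the compounds shown here alone, is how this assay responds to a methyl, a methoxy or an amine on this same carbon.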